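A few compounds are considered here, and "the series" means these few. Any claim that something is new, unique, unknown or untested is made for them only; others in the source may bear on it.

Among the measured compounds shown here, compound 2 `CC[C@H](C)[C@H](N)CN(C(=O)[C@@H]1C[C@H]1c1c(F)cccc1F)c1ccc(-c2ccccc2)cc1` is the one member of the series with a number in a functional assay for agonist activity at G protein-coupled receptor 88 (Homo sapiens), read by HTRF and cAMP accumulation; on this read-out lower numbers stand for an effect already at smaller amounts and higher numbers for an effect only at larger amounts of compound: compound 2 gives 11000 nM. Compound 1 `CC[C@H](C)[C@H](N)CN(C(=O)[C@@H]1C[C@H]1c1ccc(C#N)cc1)c1ccc(-c2ccccc2)cc1` reaches only the assay limit, > 25000 nM. For the measured compounds named here, the single measured step, an at least 2.2-fold lower number from compound 1 to compound 2 (0.35 log units; beyond the scatter), rests on that limit (the limit of > 25000 nM in this assay, at which 1 of the 2 values shown sits). Compound 3 `CC[C@H](C)[C@H](N)CN(C(=O)[C@@H]1C[C@H]1c1ccccn1)c1ccc(-c2ccccc2)cc1` differs from compound 2 by pyridin-2-yl in place of 2,6-difluorophenyl on a saturated ring carbon. Going by the values given here, no measured step involves a pyridin-2-yl; the one step known concerns a different aromatic exchange on the saturated ring carbon and sets no direction for this change. No step beyond the scatter is therefore expected, a 1.3-fold higher number from compound 2 to compound 3 (0.10 log units; within the scatter). Compound 3 is estimated at 14000 nM in this assay, between 5000 nM and 40000 nM.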

Compound 3, half-maximal effective concentration: 130 nM
Compound 3: middle estimate off by 110-fold (2.03 log units), on the high side, and the stated range ends above it.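

Pyridin-2-yl on the saturated ring carbon shows that this position can move the read-out far more than the earlier pair suggested: in this assay there is an 85-fold lower number from compound 2 to compound 3 (1.93 log units; beyond the scatter). The comparison with the 4-cyanophenyl compound gives an at least 190-fold lower number from compound 1 to compound 3 (2.28 log units; beyond the scatter), a step that rests on a limit: the limit of > 25000 nM in this assay, at which 1 of the 3 values shown sits. Of the three groups shown, the one with a hetero atom in the ring stands well apart from the two carbon-only rings.

As far as these compounds go, what plain phenyl, pyridin-3-yl or pyrimidin-2-yl would give here stays open. The compounds shown therefore cannot separate the entry of the ring nitrogen from the loss of the two fluorines.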